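From Methyl to Trifluoromethoxy at a Clearance Limit

The source may hold more compounds than are shown below. What is called first, only, known or untested is meant among the compounds shown, and "the series" means these compounds.

Three close relatives have been measured so far. In an in vitro ADME assay on microsomes from liver (Mus musculus) for pharmacokinetics, read by LC-MS (on this read-out lower numbers stand for slow clearance and higher numbers for fast clearance), compound 1 `Cc1cccc2c1nc(C)n2-c1ccc(C(=O)NC2CC2)s1` gives 66 mL/min/kg as a true number. Compound 2 `Cc1ccc2c(c1)nc(C)n2-c1ccc(C(=O)NC2CC2)s1` reads > 72 mL/min/kg and this is a limit, not a number. Compound 3 `Cc1ccc2nc(C)n(-c3ccc(C(=O)NC4CC4)s3)c2c1` reads > 72 mL/min/kg and this too is only a limit. Compound 3 thus stands at the limit of > 72 mL/min/kg in this assay, at which 2 of the 3 values shown sit, with no number of its own.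

Among the measured compounds shown here, compound 4 `Cc1nc2ccc(OC(F)(F)F)cc2n1-c1ccc(C(=O)NC2CC2)s1` keeps the rest of compound 3 but carries trifluoromethoxy in place of methyl on an aromatic carbon as its single change. For the measured compounds named here, no measured pair here shows what such a swap does in this assay so the expectation is a cautious one: a small downward move, no larger than the usual scatter. Going by the values given here, the only true number available, compound 1 at 66 mL/min/kg, anchors that expectation. The expected step is an at least 1.2-fold lower number from compound 3 to compound 4 (0.07 log units; that floor lies within the scatter) and it stays within the scatter. Compound 4 is estimated at 60 mL/min/kg with an expected range from 35 mL/min/kg to 75 mL/min/kg in this measurement.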

Compound 4, clearance: 41 mL/min/kg
The estimate for compound 4 lay 1.5-fold (0.17 log units) above the measured number, and the stated range covers the measured number.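

Compound 3 reads only a limit, not a number: the limit of > 72 mL/min/kg in this assay, at which 2 of the 4 values shown sit.

Trifluoromethoxy in place of methyl on an aromatic carbon gives the first step in this set that can be read, an at least 1.7-fold lower number from compound 3 to compound 4 (0.24 log units; that floor lies within the scatter) in this assay, and at this position compound 4 now carries a true number. That step is only a floor, so the real size cannot be read, and the measurements do not tell what in the swap stands behind it.

On these data alone, whether methoxy or trifluoromethyl on the same aromatic carbon would also give a true number stays open. So does the question of whether the same swap on compound 1 or compound 2 would give a step of similar size.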